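Pyrrolidine amide in place of methylamide on a chalcone

The compounds below may be only part of what the source reports. "The series", "measured", "known", "first", "only" and "open" are said of these compounds alone.

The three measured compounds share one core and differ only in the group on the carbonyl carbon of the aryl acid or amide. Compound 1 `COc1ccc(OC)c(C(=O)/C=C/c2ccc(C(=O)O)cc2)c1` carries the free acid and in a functional assay on PC-3 cells (Homo sapiens) for cytotoxicity, read by MTT assay, with a stated time of 72 h (a higher number here means a weaker inhibitor, a lower number a stronger inhibitor), compound 1 gives 7240 nM. Compound 2 `CNC(=O)c1ccc(/C=C/C(=O)c2cc(OC)ccc2OC)cc1` carries the methylamide, and compound 2 gives 2130 nM; the step of a 3.4-fold lower number from compound 1 to compound 2 (0.53 log units; beyond the scatter) is the only one among these three that lies beyond the scatter. Compound 3 `CCNC(=O)c1ccc(/C=C/C(=O)c2cc(OC)ccc2OC)cc1` carries the ethylamide and gives 4180 nM, so that a 2.0-fold higher number from compound 2 to compound 3 (0.29 log units; within the scatter) and a 1.7-fold lower number from compound 1 to compound 3 (0.24 log units; within the scatter) both stay within the scatter. Compound 2 therefore sits at one end of the small set, separated clearly only from compound 1.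

Compound 4 `COc1ccc(OC)c(C(=O)/C=C/c2ccc(C(=O)N3CCCC3)cc2)c1` is the next step from compound 2: pyrrolidin-1-yl in place of methylamino on a carbonyl carbon. The step that bears on it most directly is a 2.0-fold higher number from compound 2 to compound 3 (0.29 log units; within the scatter), where adding a methyl on the saturated chain carbon bound to the amide-type nitrogen changed little. Pyrrolidin-1-yl goes further in the same sense and removes the hydrogen-bond donor, so a somewhat weaker result is expected, but not a large one: the expected step is a 1.6-fold higher number from compound 2 to compound 4 (0.22 log units; within the scatter). Compound 4 is estimated at 3500 nM, with a likely range from 1500 nM to 9000 nM.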

Compound 4, half-maximal inhibitory concentration: 530 nM
The estimate for compound 4 lay 6.6-fold (0.82 log units) above the measured number; measured number outside the range, below it.
By their numbers in this assay, from the lowest: compound 4; then compounds 2, 3 and 1 (each within the scatter of the next, the first and the last beyond it).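

In this assay, the group on the carbonyl carbon proves able to move the number well beyond what the two open-chain amides showed: a 4.0-fold lower number from compound 2 to compound 4 (0.60 log units; beyond the scatter) and a 7.9-fold lower number from compound 3 to compound 4 (0.90 log units; beyond the scatter) are both beyond the scatter, whereas methylamino and ethylamino stayed within it of each other. With a 14-fold lower number from compound 1 to compound 4 (1.14 log units; beyond the scatter) as the largest step in the set, compound 4 is the only compound whose steps to all three others lie beyond the scatter, so the amide hydrogen, present in compound 2 and compound 3 but absent from compound 4, is not needed for the lowest number among these compounds. Nothing measured here gives a reason for this gain.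

The compounds shown cannot separate the contribution of the ring from that of losing the amide hydrogen, and an open-chain dimethylamino group on the same carbonyl carbon would bear directly on that question. Whether the gain depends on ring size or on the ring's atoms also stays open, as piperidin-1-yl and morpholin-4-yl are not among the compounds shown.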